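The compounds below may be only part of what the source reports. "The series", "measured", "known", "first", "only" and "open" are said of these compounds alone.

Compound 1 `Cc1ncccc1C(=O)NCCC1CCN(S(=O)(=O)NC(=O)NC2CCCCC2)CC1` and compound 2 `Cc1ncccc1C(=O)NCCC1CCN(S(=O)(=O)NC(=O)NC[C@@H]2C[C@@H]3C=C[C@@H]2C3)CC1` share one core and differ in a single place: a group of 8 heavy atoms (8 carbon; 2 five-membered non-aromatic rings of carbon only) in place of a group of 6 heavy atoms (6 carbon; one six-membered non-aromatic ring of carbon only), on an amide-type nitrogen. In a functional assay on the whole organism (blood) with Rattus norvegicus as the target, with stated times of 24 h and 1 h, at a dose of 5 mg/kg by the intraperitoneal route (a higher number here means a stronger effect of the compound at the dose given, a lower number a weaker effect), compound 1 gives 16%, and compound 2 gives 16%; the step between them is no change at the digits printed from compound 1 to compound 2 (within the scatter). Compound 3 `O=C(NC1CCCCC1)NS(=O)(=O)N1CCC(CCNC(=O)c2cccc3c2OCCO3)CC1` carries a second core, which differs from the core of compound 1 in one place: 2,3-dihydro-1,4-benzodioxin-5-yl in place of 2-methylpyridin-3-yl on a carbonyl carbon. In this assay compound 3 gives 34%, which is a number 18 percentage points higher from compound 1 to compound 3 (beyond the scatter), and it stands highest of the three measured numbers. Compound 4 `O=C(NC[C@@H]1C[C@@H]2C=C[C@@H]1C2)NS(=O)(=O)N1CCC(CCNC(=O)c2cccc3c2OCCO3)CC1` has not yet been measured; it differs from compound 3 by the same change already seen between the first two compounds: a group of 8 heavy atoms (8 carbon; 2 five-membered non-aromatic rings of carbon only) in place of a group of 6 heavy atoms (6 carbon; one six-membered non-aromatic ring of carbon only), on an amide-type nitrogen. Because this change gave no change at the digits printed from compound 1 to compound 2 (within the scatter) on the first core, the same change on the core of compound 3 is expected to give a similar outcome, no change at the digits printed from compound 3 to compound 4 (within the scatter). Whether the second core answers this change like the first rests on one measured pair alone. Compound 4 is therefore estimated at 34% in this assay, with a likely range from 22% to 46%.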

Compound 4, a percentage reported as activity, at one dose (the size of the read-out at that dose, not a potency): 11%
For compound 4 the middle estimate is 23 percentage points above the measured one, outside the stated range (below it).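

In this assay the group of 8 carbon atoms with two five-membered rings, in place of cyclohexyl on the amide-type nitrogen, does not carry over from one core to the other: it gives a number 23 percentage points lower from compound 3 to compound 4 (beyond the scatter), and the two cores do not answer alike: the same change on two cores in this assay, no change at the digits printed (within the scatter) from compound 1 to compound 2 and a number 23 percentage points lower (beyond the scatter) from compound 3 to compound 4, 23 percentage points apart, beyond the scatter of two such steps. The other change, 2,3-dihydro-1,4-benzodioxin-5-yl in place of 2-methylpyridin-3-yl on a carbonyl carbon, likewise depends on what sits on the amide-type nitrogen, giving a number 5 percentage points lower from compound 2 to compound 4 (within the scatter), set against the earlier step: the same change on two cores in this assay, a number 18 percentage points higher (beyond the scatter) from compound 1 to compound 3 and a number 5 percentage points lower (within the scatter) from compound 2 to compound 4, 23 percentage points apart, beyond the scatter of two such steps. Both comparisons rest on the same four compounds, so they show that the two changes do not act independently here, but not why, nor how either change would behave on a third core.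

The compounds shown leave open whether this dependence holds for other groups on the amide-type nitrogen, such as cyclopentyl or phenyl. They also leave open how a simple phenyl or a methoxyphenyl on the carbonyl carbon would respond to the same exchange.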